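Acetyl to ethoxycarbonyl on the bromo-chloro coumarin core

The source may hold more compounds than are shown below. What is called first, only, known or untested is meant among the compounds shown, and "the series" means these compounds.

The series is followed in an in vitro assay on BTI-TN-5B1-4 cells for inhibition of Amine oxidase [flavin-containing] B (Homo sapiens), read by fluorescence, with a stated time of 15 min; on this read-out lower numbers stand for stronger inhibition and higher numbers for weaker inhibition. Compound 1 `CC(=O)c1cc2cc(Cl)ccc2oc1=O` gives 17700 nM in this assay. Going by the values given here, compound 2 `CC(=O)c1cc2cc(Cl)cc(Br)c2oc1=O` gives 140 nM; the single change, a 130-fold lower number from compound 1 to compound 2 (2.10 log units; beyond the scatter), is the only one-place step measured so far. Compound 3 `O=C(c1ccccc1)c1cc2cc(O)ccc2oc1=O` gives 18000 nM; it differs from compound 1 in two places, so only its number is known. Compound 2 thus stands lowest of the three in this assay, far from both compound 1 and compound 3.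

Compound 4 `CCOC(=O)c1cc2cc(Cl)cc(Br)c2oc1=O` keeps the core of compound 2 and carries ethoxy in place of methyl on a carbonyl carbon. Among the compounds with values here, no measured step touches the carbonyl substituent: the only step available concerns the ring halogen, and compound 3 changes the carbonyl substituent together with the ring substituent. Within the data shown here, there is therefore no precedent for the size or direction of this change in this assay. A modest step is expected, a 2.1-fold higher number from compound 2 to compound 4 (0.33 log units; beyond the scatter), with the direction left open. Compound 4 is estimated at 300 nM, in the range 60 nM to 1500 nM.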

Compound 4, half-maximal inhibitory concentration: 17500 nM
The estimate for compound 4 lay 58-fold (1.77 log units) below the measured number; measured number outside the range, above it.
By their numbers in this assay, from the lowest: compound 2; then compounds 4, 1 and 3 (each within the scatter of the next).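

In this assay, ethoxy in place of methyl on a carbonyl carbon is far from a neutral exchange on this core (a 130-fold higher number from compound 2 to compound 4 (2.10 log units; beyond the scatter)). The step runs against the earlier bromo step (a 130-fold lower number from compound 1 to compound 2 (2.10 log units; beyond the scatter)), so the low number of compound 2 depends on the acetyl as well as on the bromo, at least in this one pair. No data at hand bear on what lies behind this step.

Only one replacement of the methyl is shown, so it stays open whether the rise follows the added oxygen or the longer chain; an ethyl ketone, a methyl ester or a carboxylic acid at this carbon would separate these. Also open, on these data alone, is whether bromo in place of hydrogen still lowers the number when ethoxycarbonyl is present.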